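The source may report more compounds than this note shows. Statements on the series, on what has been measured and on what is new or still open speak of the compounds shown alone.

Series notes. Compound 1 `O=C(COc1ccc(Cl)cc1)Nc1nc(-c2ccc(Br)cc2)cs1` gives 51700 nM in a functional assay on MDA-MB-468 cells (Homo sapiens) for cytotoxicity, read by trypan blue exclusion, with a stated time of 48 h; on this read-out lower numbers stand for stronger inhibition and higher numbers for weaker inhibition. Compound 2 `O=C(COc1ccc(Cl)cc1)Nc1nc(-c2ccc(Cl)cc2)cs1` gives 56800 nM; the change chloro in place of bromo on an aromatic carbon made the step of a 1.1-fold higher number from compound 1 to compound 2 (0.04 log units; within the scatter). Compound 3 `Cc1ccc(OCC(=O)Nc2nc(-c3ccc(Br)cc3)cs2)cc1` gives 44500 nM; the core of compound 3 differs from that of compound 1 by methyl in place of chloro on an aromatic carbon, with the step of a 1.2-fold lower number from compound 1 to compound 3 (0.07 log units; within the scatter). Compound 4 `Cc1ccc(OCC(=O)Nc2nc(-c3ccc(Cl)cc3)cs2)cc1` is not yet measured. It differs from compound 3 by chloro in place of bromo on an aromatic carbon, the same change as from compound 1 to compound 2, made twice in all within this set of four compounds, and at the same kind of place. On the basis of the step of a 1.1-fold higher number from compound 1 to compound 2 (0.04 log units; within the scatter), the step from compound 3 to compound 4 is expected to be a 1.1-fold higher number from compound 3 to compound 4 (0.03 log units; within the scatter). Compound 4 is therefore estimated at 48000 nM, within 30000 nM to 76000 nM.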

Compound 4, half-maximal inhibitory concentration: 50100 nM
The estimate for compound 4 lay 1.0-fold (0.02 log units) below the measured number, within the range that was stated.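

In this assay, the 4-bromophenyl to 4-chlorophenyl change gives a 1.1-fold higher number from compound 3 to compound 4 (0.05 log units; within the scatter), and it reads alike on both cores: the same change on two cores in this assay, a 1.1-fold higher number (0.04 log units; within the scatter) from compound 1 to compound 2 and a 1.1-fold higher number (0.05 log units; within the scatter) from compound 3 to compound 4, 1.0-fold (0.01 log units) apart, within the scatter of two such steps

Methyl in place of chloro gives a 1.1-fold lower number from compound 2 to compound 4 (0.05 log units; within the scatter), which also agrees with its earlier counterpart: the same change on two cores in this assay, a 1.2-fold lower number (0.07 log units; within the scatter) from compound 1 to compound 3 and a 1.1-fold lower number (0.05 log units; within the scatter) from compound 2 to compound 4, 1.0-fold (0.01 log units) apart, within the scatter of two such steps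

Going by these compounds alone, every one of these steps lies within the scatter, so the agreement shows only that neither change gives a measurable step on these cores; it does not show that a step of real size would carry from one core to another, or that either change would behave alike on a different core.

The compounds shown leave open whether an amine or a carboxylic acid on either aromatic ring, in place of the halogen or methyl, would give a step beyond the scatter. The same question stands for a longer chain in place of the one joining the ether oxygen to the amide carbonyl.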